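From 3-chlorophenyl to 4-methoxyphenyl: an expected rise

The source may report more compounds than this note shows. Statements on the series, on what has been measured and on what is new or still open speak of the compounds shown alone.

In a functional assay on MDA-MB-231 cells (Homo sapiens) for antiproliferative activity, read by CCK-8 assay, with a stated time of 72 h (on this read-out lower numbers stand for stronger inhibition and higher numbers for weaker inhibition), compound 1 `COc1cccc(Nc2nc(Nc3cc(C)[nH]n3)cc(N3CCN(C)CC3)n2)c1` gives 240 nM, compound 2 `Cc1cc(Nc2cc(N3CCN(C)CC3)nc(Nc3cccc([N+](=O)[O-])c3)n2)n[nH]1` gives 114 nM and compound 3 `Cc1cc(Nc2cc(N3CCN(C)CC3)nc(Nc3cccc(Cl)c3)n2)n[nH]1` gives 56.4 nM. Compound 3 therefore holds the lowest number of the three, and its steps to both others lie beyond the scatter. Compound 4 `COc1ccc(Nc2nc(Nc3cc(C)[nH]n3)cc(N3CCN(C)CC3)n2)cc1` has not yet been measured and differs from compound 3 in one place: 4-methoxyphenyl in place of 3-chlorophenyl on a nitrogen on an aromatic ring. In words, this is 4-methoxyphenyl in place of 3-chlorophenyl on a nitrogen on an aromatic ring.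

The closest evidence is a 4.3-fold lower number from compound 1 to compound 3 (0.63 log units; beyond the scatter), where chloro replaces methoxy on an aromatic carbon. The steps of a 2.1-fold lower number from compound 1 to compound 2 (0.32 log units; beyond the scatter) and a 2.0-fold lower number from compound 2 to compound 3 (0.31 log units; beyond the scatter) show the same order among the three groups. However, the methoxy of compound 4 sits elsewhere on the ring than that of compound 1, and no measured compound shows that placement, so the range stays wide. Running the chloro step in reverse, a modest rise is expected, and the estimated step is a 3.7-fold higher number from compound 3 to compound 4 (0.57 log units; beyond the scatter). For compound 4 the estimate is 210 nM, with an expected range of 80 nM to 550 nM.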

Compound 4, half-maximal inhibitory concentration: 243 nM
Estimate against measurement, compound 4: 1.2-fold (0.06 log units) below; low and high end bracket the measured number.
By their numbers in this assay, from the lowest: compound 3; then compound 2; then compounds 1 and 4 (each within the scatter of the next).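

In this assay, among the compounds shown here, the new result shows that the placement of the methoxy group on this aryl ring, which the earlier compounds could not address, makes no readable difference: a 1.0-fold higher number from compound 1 to compound 4 (0.01 log units; within the scatter) stays within the scatter between 3-methoxyphenyl and 4-methoxyphenyl on the same nitrogen. The gaps to the other two groups are both beyond the scatter, with a 4.3-fold higher number from compound 3 to compound 4 (0.63 log units; beyond the scatter) and a 2.1-fold higher number from compound 2 to compound 4 (0.33 log units; beyond the scatter), so the 4-methoxyphenyl group falls in the same place in the order as the 3-methoxyphenyl group. Nothing measured here explains these differences.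

From the compounds shown here alone, only the methoxy group has been seen at two ring placements, so it remains open whether 4-chlorophenyl or 4-nitrophenyl would track their 3-substituted counterparts. The compounds also leave open how an unsubstituted phenyl ring, or an amine on the ring, would compare.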